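A few compounds are considered here, and "the series" means these few. Any claim that something is new, unique, unknown or untested is made for them only; others in the source may bear on it.

The measured compounds:

compound 1, `O=C(CI)NCCCCCC(=O)NCCCCCCNc1ncnc2c1ncn2[C@@H]1O[C@H](COP(=O)(O)OP(=O)(O)OP(=O)(O)O)[C@@H](O)[C@H]1O`, with 0%
compound 2, `CN(CCCCN(C)c1ncnc2c1ncn2[C@@H]1O[C@H](COP(=O)(O)OP(=O)(O)OP(=O)(O)O)[C@@H](O)[C@H]1O)C(=O)CCCNC(=O)CI`, with 0%
compound 3, `O=C(CI)NCCCC(=O)NCCCCCCNc1ncnc2c1ncn2[C@@H]1O[C@H](COP(=O)(O)OP(=O)(O)OP(=O)(O)O)[C@@H](O)[C@H]1O`, with 0%

All three were tested in an assay on isolated protein for inhibition of hexokinase-3 (Rattus norvegicus), with a stated time of 6 h, tested at 10 mM; on this read-out higher numbers stand for more inhibition at the one concentration tested (going by the name of the read-out) and lower numbers for less inhibition. Compound 1, compound 2 and compound 3 sit at the same level, with no difference among them that the scatter of the assay would allow one to call a change. Compound 3 and compound 1 differ in one place: 2-(((iodomethyl)carbonyl)amino)ethyl in place of ((iodomethyl)carbonyl)amino on a saturated chain carbon, three bonds along the chain from a carbonyl carbon. This change gave no change at the digits printed from compound 3 to compound 1 (within the scatter). Compound 2 and compound 3 are built from the same atoms joined differently; the difference between their two cores is not broken down here.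

Compound 4, `CN(CCCCN(C)c1ncnc2c1ncn2[C@@H]1O[C@H](COP(=O)(O)OP(=O)(O)OP(=O)(O)O)[C@@H](O)[C@H]1O)C(=O)CCCCCNC(=O)CI`, has not been measured. It stands to compound 2 as compound 1 stands to compound 3: 2-(((iodomethyl)carbonyl)amino)ethyl in place of ((iodomethyl)carbonyl)amino on a saturated chain carbon, three bonds along the chain from a carbonyl carbon. The place of the change reads the same for both pairs, so the change is the same kind of change, made here on the core of compound 2 rather than the core of compound 3. In this assay the step from compound 2 to compound 4 is expected to be no change at the digits printed from compound 2 to compound 4 (within the scatter), set beside the measured no change at the digits printed from compound 3 to compound 1 (within the scatter). This rests on compound 3 giving 0% and compound 1 giving 0%, and on compound 2 giving 0%, all at one level. For compound 4 the expected value is therefore 0%, with a likely range from 0% to 10%.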

Compound 4, a percentage reported as inhibition, at one concentration (the size of the read-out at that concentration, not a potency): 0%
Compound 4: the middle estimate sits on the measured number at the digits printed; low and high end bracket the measured number.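

In this assay, putting 2-(((iodomethyl)carbonyl)amino)ethyl in place of ((iodomethyl)carbonyl)amino on the core of compound 2 gives no change at the digits printed from compound 2 to compound 4 (within the scatter), and this matches what the same change did on the other core: the same change on two cores in this assay, no change at the digits printed (within the scatter) from compound 3 to compound 1 and no change at the digits printed (within the scatter) from compound 2 to compound 4, 0 percentage points apart, within the scatter of two such steps

So, within these four compounds, the change has the same outcome on both cores, and swapping one core for the other alters nothing that this read-out can detect. This agreement is weak evidence, however: all four compounds, compound 4 included, sit at 0%, so neither pair starts from any inhibition that the change could raise or lower, and two flat steps cannot show that the change would carry over in the same way in a compound that does inhibit the enzyme.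

The compounds shown leave open whether any member of this series inhibits hexokinase-3 to a measurable degree, and so what the change would do in such a compound. As far as these compounds go, it also remains open whether a longer chain, or an amine or a carboxylic acid in place of the ((iodomethyl)carbonyl)amino group, would give a different reading on either core.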